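Swapping the aryl group on the sulfonyl sulfur

The source may report more compounds than this note shows. Statements on the series, on what has been measured and on what is new or still open speak of the compounds shown alone.

Of the compounds shown here, three sharing one core have been tested in an assay on isolated protein for displacement of a labelled ligand from metabotropic glutamate receptor 5 (Homo sapiens), with a stated time of 60 min, tested at 1 uM; on this read-out lower numbers stand for less inhibition and higher numbers for more inhibition at the one concentration tested (going by the name of the read-out). Compound 1 `CC1CCN(c2c(S(=O)(=O)c3ccccc3)cnc3cc(Cl)ccc23)CC1` carries a phenyl on the sulfonyl sulfur and gives 93%. Compound 2 `CC1CCN(c2c(S(=O)(=O)c3ccc(F)c(F)c3)cnc3cc(Cl)ccc23)CC1`, with 3,4-difluorophenyl there, gives 90%. Compound 3 `CC1CCN(c2c(S(=O)(=O)c3cc(F)cc(F)c3)cnc3cc(Cl)ccc23)CC1`, with 3,5-difluorophenyl, gives 94%, the highest of the three numbers, though every gap to it is within the scatter: a number 1 percentage points higher from compound 1 to compound 3 (within the scatter) and a number 4 percentage points higher from compound 2 to compound 3 (within the scatter). The remaining pair shows a number 3 percentage points lower from compound 1 to compound 2 (within the scatter).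

Compound 4 `Cc1ccc(S(=O)(=O)c2cnc3cc(Cl)ccc3c2N2CCC(C)CC2)cc1` has not yet been measured in this assay. It differs from compound 3 in one place: 4-methylphenyl in place of 3,5-difluorophenyl on a sulfonyl sulfur. All three measured steps change the same aryl group on the sulfonyl sulfur, and none of them moves the read-out beyond the scatter. On that basis no step beyond the scatter is expected here either, so the estimate is a number 3 percentage points lower from compound 3 to compound 4 (within the scatter). Compound 4 is therefore expected to give about 91% in this assay, with a likely range from 80% to 97%.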

Compound 4, a percentage reported as inhibition, at one concentration (the size of the read-out at that concentration, not a potency): 94%
The estimate for compound 4 lay 3 percentage points below the measured number, within the range that was stated.
By their numbers in this assay, from the lowest: compounds 2, 1, 3 and 4 (each within the scatter of the next).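

Compounds 1, 2 and 3 carried only hydrogen or fluorine on this aryl ring, and compound 4 now shows that in this assay the 4-methylphenyl group fits the same picture: there is no change at the digits printed from compound 3 to compound 4 (within the scatter) and a number 4 percentage points higher from compound 2 to compound 4 (within the scatter) and a number 1 percentage points higher from compound 1 to compound 4 (within the scatter) in this series. Within the data shown here, at the one concentration tested, this position on the sulfonyl sulfur therefore takes a methyl as readily as fluorine, with no compound among the four standing apart from the others. No measurement at hand explains why these swaps leave the number in place.

On these data alone, whether an aryl ring carrying an amine or a carboxylic acid would keep the number in this range remains open. Any potency differences among the four also stay open, as a single concentration cannot separate them.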